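A few compounds are considered here, and "the series" means these few. Any claim that something is new, unique, unknown or untested is made for them only; others in the source may bear on it.

- Compound 1 `C/C(=N\NC(=O)/C(C#N)=C/c1ccc(O)cc1)c1c(O)c2ccc(O)cc2oc1=O`: 6230 nM
- Compound 2 `COc1ccc(/C=C(\C#N)C(=O)N/N=C(\C)c2c(O)c3ccc(O)cc3oc2=O)cc1OC`: 14300 nM

In a functional assay on A549 cells (Homo sapiens) for cytotoxicity, read by MTT assay, with a stated time of 24 h (on this read-out lower numbers stand for stronger inhibition and higher numbers for weaker inhibition), compound 2 gives 14300 nM, the higher of the two numbers. Compound 3 `C/C(=N\NC(=O)/C(C#N)=C/c1ccc(Br)cc1)c1c(O)c2ccc(O)cc2oc1=O` differs from it as follows: 4-bromophenyl in place of 3,4-dimethoxyphenyl on a double-bonded chain carbon bound to a double-bonded chain carbon. Within the data shown here, one measured step bears on this place, a 2.3-fold higher number from compound 1 to compound 2 (0.36 log units; beyond the scatter). It is modest, though beyond the scatter. Among the measured compounds shown here, compound 3, like compound 1, lacks the 3,4-dimethoxyphenyl, so a modest step toward a lower number is expected, but with little certainty, as no bromine-bearing compound has been measured. The estimated change is a 1.6-fold lower number from compound 2 to compound 3 (0.20 log units; within the scatter). For compound 3 the expected value is 9000 nM, within an estimated range of 4000 nM to 20000 nM.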

Compound 3, half-maximal inhibitory concentration: 11400 nM
Compound 3: middle estimate off by 1.3-fold (0.10 log units), on the low side; the range from low to high includes it.
By their numbers in this assay, from the lowest: compounds 1, 3 and 2 (each within the scatter of the next, the first and the last beyond it).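

In this assay, 4-bromophenyl in place of 3,4-dimethoxyphenyl gives a 1.3-fold lower number from compound 2 to compound 3 (0.10 log units; within the scatter), and bromo in place of hydroxy on an aromatic carbon gives a 1.8-fold higher number from compound 1 to compound 3 (0.26 log units; within the scatter). Both steps lie within the scatter, so compound 3 cannot be told apart from either compound, although compound 1 and compound 2 differ beyond it. Nothing at hand accounts for these results.

On these data alone, what an amine or a carboxylic acid on that aromatic carbon would give remains open. So does whether a longer chain on the oxygen of the hydroxy group would change the number.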